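The source may report more compounds than this note shows. Statements on the series, on what has been measured and on what is new or still open speak of the compounds shown alone.

Measured so far:
- compound 1 `C[C@@H]1CN(C(=O)[C@H](CC2CCCCC2)OC(=O)N[C@@H](C)CN2CC(C)(C)c3cc(F)ccc32)C[C@H](C)O1`, in an assay on isolated protein for inhibition of cathepsin S (Homo sapiens) (on this read-out higher numbers stand for weaker inhibition and lower numbers for stronger inhibition), compound 1 gives 297 nM
- compound 2 `C[C@@H](CN1CC(C)(C)c2cc(F)ccc21)NC(=O)O[C@@H](CC1CCCCC1)C(=O)N(C)C`, in this assay compound 2 gives 227 nM

Compound 2 and compound 1 share a common core and differ only in the group on the carbonyl carbon at one end. The step of a 1.3-fold lower number from compound 1 to compound 2 (0.12 log units; within the scatter) lies within the usual scatter, so the two compounds cannot be told apart on the numbers shown, and compound 2 stands beside compound 1 rather than apart from it.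

Compound 3 `C[C@@H](CN1CC(C)(C)c2cc(F)ccc21)NC(=O)O[C@@H](CC1CCCCC1)C(=O)N1CCC1` is not yet measured. It differs from compound 2 by azetidin-1-yl in place of dimethylamino on a carbonyl carbon. Among the measured compounds shown here, the only measured step that bears on this place, a 1.3-fold lower number from compound 1 to compound 2 (0.12 log units; within the scatter), swapped one amine on that same carbonyl for another and produced nothing beyond the scatter. On that basis the change to compound 3 is expected to give no step beyond the scatter, a 1.0-fold lower number from compound 2 to compound 3 (0.01 log units; within the scatter). Compound 3 is therefore estimated at 220 nM, within a range from 100 nM to 500 nM.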

Compound 3, inhibition constant: 217 nM
Estimate against measurement, compound 3: 1.0-fold (0.01 log units) above; measured number inside the range.
By their numbers in this assay, from the lowest: compounds 3, 2 and 1 (each within the scatter of the next).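

In this assay, tying the dimethylamino group into azetidin-1-yl on the carbonyl carbon brings in a four-membered ring where there was none, and the result is a 1.0-fold lower number from compound 2 to compound 3 (0.02 log units; within the scatter) with no move beyond the scatter. Set against 2,6-dimethylmorpholin-4-yl, the same group gives a 1.4-fold lower number from compound 1 to compound 3 (0.14 log units; within the scatter) and again stays within the scatter, so all three amine groups at this position, open-chain and ring alike, cannot be told apart on these numbers. No measurement is available to explain this flat result.

Still open, as far as these compounds go, is whether an amine group carrying a carboxylic acid, or a piperidine ring, would shift the number beyond the scatter at this position. Also open, from the compounds shown here alone, is what a plain ethyl chain would do there, with no nitrogen on the carbonyl at all.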